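This account rests on a few compounds, and the source may have more. Where it says the series, first, only, none or still open, it means among the compounds named here.

In an ADME assay on Vero cells (Chlorocebus sabaeus) for cytotoxicity, read by resazurin assay, with a stated time of 72 h (a lower number here means a stronger inhibitor, a higher number a weaker inhibitor), compound 1 `Cc1ccc(C(=O)CCN2CCN(c3ccc(C(F)(F)F)cc3)CC2)cc1` gives 140000 nM and compound 2 `O=C(CCN1CCN(c2ccc(C(F)(F)F)cc2)CC1)c1ccc(C(F)(F)F)cc1` gives 49200 nM. Compound 3 `O=C(CCN1CCN(c2ccc(F)cc2)CC1)c1ccc(OC(F)(F)F)cc1` gives 70300 nM. That number lies within the usual scatter of both others, so compound 3 cannot be separated from either of them, although compound 1 and compound 2 can be separated from each other.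

Compound 4 `O=C(CCN1CCN(c2ccc(C(F)(F)F)cc2)CC1)c1ccc(OC(F)(F)F)cc1` has not yet been measured. It differs from compound 3 by a single swap: trifluoromethyl in place of fluoro on an aromatic carbon. Trifluoromethyl takes the place of fluoro on an aromatic carbon, para to a large group.

Within the data shown here, only one measured step brings in the same group: a 2.8-fold lower number from compound 1 to compound 2 (0.45 log units; beyond the scatter). There, however, trifluoromethyl replaced methyl rather than fluoro, and on a different ring, so this single pair is only a rough guide. It suggests a lower number in this assay, and a step in that direction of similar or smaller size is expected here, possibly no larger than the scatter. The estimated step is a 1.8-fold lower number from compound 3 to compound 4 (0.24 log units; within the scatter). For compound 4 the expected value is 40000 nM, with an estimated range from 18000 nM to 85000 nM.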

Compound 4, half-maximal inhibitory concentration: 64900 nM
Beside the measured number, compound 4's estimate is 1.6-fold (0.21 log units) below it, within the range that was stated.
By their numbers in this assay, from the lowest: compounds 2, 4, 3 and 1 (each within the scatter of the next, the first and the last beyond it).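

In this assay, replacing fluoro with trifluoromethyl on an aromatic carbon para to a large group gives a 1.1-fold lower number from compound 3 to compound 4 (0.03 log units; within the scatter) and so does not separate the two compounds, even though the group grows from 1 heavy atom to 4. At the aromatic carbon that carries methyl in compound 1, trifluoromethoxy and trifluoromethyl also cannot be told apart, with a 1.3-fold higher number from compound 2 to compound 4 (0.12 log units; within the scatter) as their step, whereas trifluoromethoxy in place of methyl gives a 2.2-fold lower number from compound 1 to compound 4 (0.33 log units; beyond the scatter) and is beyond the scatter, like the earlier 2.8-fold lower number from compound 1 to compound 2 (0.45 log units; beyond the scatter) for trifluoromethyl in place of methyl. Among these four compounds, then, only the two steps away from the methyl group of compound 1 can be read as real differences, and nothing available explains those steps or the absence of a clear step elsewhere.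

The two varied places carry only fluoro, trifluoromethyl, methyl and trifluoromethoxy in the compounds shown, so the effect of an amine or a carboxylic acid at either place remains open. Also open, on these data alone, is whether a longer chain in the shared core would shift the number in this assay at all.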